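Anilide series against thiosulfate sulfurtransferase: working notes

The source may hold more compounds than are shown below. What is called first, only, known or untested is meant among the compounds shown, and "the series" means these compounds.

Measured compounds:
Compound 1 `COc1ccc(Br)cc1C(=O)Nc1ccc(Sc2nc3ccccc3s2)cc1` in an assay on isolated protein for inhibition of thiosulfate sulfurtransferase (Homo sapiens), with a stated time of 60 min, in the absence of a further agent (on this read-out lower numbers stand for stronger inhibition and higher numbers for weaker inhibition), gives > 100000 nM, a limit of the assay rather than a number.
Compound 2 `COc1c(Br)cc(Br)cc1C(=O)Nc1cccc(Cl)c1` in this assay gives > 100000 nM, likewise only a limit.

Compound 1 thus stands at the limit, as does compound 2 (the limit of > 100000 nM in this assay, at which 2 of the 2 values shown sit); no numerical value anchors the series. Compound 3 `O=C(Nc1ccc(Sc2nc3ccccc3s2)cc1)c1cc(Br)cc(Br)c1O` carries 3,5-dibromo-2-hydroxyphenyl in place of 5-bromo-2-methoxyphenyl on a carbonyl carbon. Among the measured compounds shown here, no step between measured compounds is available, so the direction of change is not fixed by the data; the expected step in this assay is an at least 1.2-fold lower number from compound 1 to compound 3 (0.09 log units; that floor lies within the scatter), not clearly beyond the scatter. For compound 3 the expected value is 80000 nM, in the range 10000 nM to 300000 nM, and most probably the assay will again report only a limit.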

Compound 3, half-maximal inhibitory concentration: > 100000 nM
Compound 3: a limit, no number; the forecaster's own chance of this, stated with the estimate: 60%; middle value at least 1.2-fold (0.09 log units) from the limit.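

Among the compounds shown here, compound 1 and compound 3 both stand at the assay limit, so no step between them can be read: the limit of > 100000 nM in this assay, at which 3 of the 3 values shown sit. Whether 3,5-dibromo-2-hydroxyphenyl in place of 5-bromo-2-methoxyphenyl changes inhibition at all stays open; no compound shown gives a number.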